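Urea pyrazole series: methoxy to hydroxy on the aryl

A few compounds are considered here, and "the series" means these few. Any claim that something is new, unique, unknown or untested is made for them only; others in the source may bear on it.

Measured so far:
compound 1, `O=C(Nc1cccc(-n2cc(-c3ccncc3)c(-c3ccc(Cl)c(O)c3)n2)c1)Nc1cccc(C(F)(F)F)c1`: 26800 nM
compound 2, `COc1cc(-c2nn(-c3cccc(NC(=O)Nc4ccc(Cl)c(Cl)c4)c3)cc2-c2ccncc2)ccc1Cl`: 1920 nM

For the measured compounds named here, in a functional assay on MDA-MB-231 cells (Homo sapiens) for inhibition, read by sulforhodamine B assay, with a stated time of 48 h (on this read-out lower numbers stand for stronger inhibition of growth and higher numbers for weaker inhibition of growth), compound 2 gives 1920 nM, the lowest of the two numbers measured so far. Compound 1 gives 26800 nM, a higher number that lies beyond the scatter. Going by the values given here, compound 1 and compound 2 differ in two places at once, so no single step between them can be read from their values.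

Compound 3, `O=C(Nc1cccc(-n2cc(-c3ccncc3)c(-c3ccc(Cl)c(O)c3)n2)c1)Nc1ccc(Cl)c(Cl)c1`, is derived from compound 2 by one change: hydrogen in place of methyl on an oxygen on an aromatic ring. Compound 3 thereby carries the same hydroxy group as compound 1 while keeping the dichlorophenyl urea of compound 2. Among the compounds with values here, no measured pair isolates this change, so its size is not known from the data. Within the data shown here, compound 1, the only hydroxy compound measured, sits at the weaker end of the numbers, which leaves room for a move toward higher numbers. The step from compound 2 to compound 3 is expected to be a 2.6-fold higher number from compound 2 to compound 3 (0.42 log units; beyond the scatter), toward weaker inhibition of growth. For compound 3 an estimate of 5000 nM is proposed, with a range from 1500 nM to 20000 nM.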

Compound 3, concentration for total growth inhibition: 8330 nM
Estimate against measurement, compound 3: 1.7-fold (0.22 log units) below; low and high end bracket the measured number.
By their numbers in this assay, from the lowest: compound 2; then compound 3; then compound 1.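

In this assay, the oxygen on the aromatic ring now has a measured step of its own: methoxy to hydroxy gives a 4.3-fold higher number from compound 2 to compound 3 (0.64 log units; beyond the scatter), so within the 3,4-dichlorophenyl compounds the free hydroxy goes with weaker inhibition of growth, beyond the scatter. Compound 3 also keeps the hydroxy group constant against compound 1 and isolates the aryl group on the amide-type nitrogen, where 3,4-dichlorophenyl in place of 3-(trifluoromethyl)phenyl gives a 3.2-fold lower number from compound 1 to compound 3 (0.51 log units; beyond the scatter), a step toward stronger inhibition of growth, also beyond the scatter. The two changes that were tangled between compound 1 and compound 2 can therefore each be read as a single step in opposite directions, but nothing on hand accounts for either one.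

The compounds shown leave open whether methoxy to hydroxy has a step of similar size when 3-(trifluoromethyl)phenyl sits on the amide-type nitrogen, since each change is seen in one setting only. They also leave open how an amine or a longer ether such as ethoxy would compare with methoxy and hydroxy at this place on the aromatic ring.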